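The compounds below may be only part of what the source reports. "The series", "measured", "known", "first", "only" and "open" are said of these compounds alone.

Measured so far:
compound 1 `Brc1cccc(C2=NCCCC2)c1` — 29.8 nM
compound 2 `c1ccc(C2=NCCCC2)cc1` — 194 nM

In an assay on HEK293 cells for displacement of a labelled ligand from Neuronal acetylcholine receptor; alpha3/beta4 (Homo sapiens), read by radioligand binding, with a stated time of 5 min (on this read-out higher numbers stand for weaker inhibition and lower numbers for stronger inhibition), compound 2 gives 194 nM, the highest of the two numbers; its nearest neighbour, compound 1, gives 29.8 nM. For the measured compounds named here, the single measured step, a 6.5-fold higher number from compound 1 to compound 2 (0.81 log units; beyond the scatter), shows that replacing bromo on the aromatic carbon with hydrogen weakens binding beyond the scatter.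

Compound 3 `Clc1cccc(C2=NCCCC2)c1` differs from compound 2 by chloro in place of hydrogen on an aromatic carbon. The step that bears on it is a 6.5-fold higher number from compound 1 to compound 2 (0.81 log units; beyond the scatter), the loss of a halogen from the same aromatic ring, which raised the number by a modest amount. Re-entering a halogen, here chloro, is therefore expected to run the other way: a lowering step of about a 4.3-fold lower number from compound 2 to compound 3 (0.63 log units; beyond the scatter), probably somewhat smaller than the bromo step, since two halogens need not be identical in effect. Compound 3 is thus estimated at 45 nM in this assay, with a range of 20 nM to 110 nM.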

Compound 3, inhibition constant: 77.2 nM
Compound 3: the middle estimate sits 1.7-fold (0.23 log units) below what was measured, and the stated range covers the measured number.
By their numbers in this assay, from the lowest: compound 1; then compound 3; then compound 2.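

In this assay chloro on this aromatic carbon also lowers the number relative to hydrogen, with a 2.5-fold lower number from compound 2 to compound 3 (0.40 log units; beyond the scatter) showing that the lowering seen with bromo is not confined to one halogen in this pair of compounds. The two halogens are not interchangeable at this position, since the exchange of bromo for chloro gives a 2.6-fold higher number from compound 1 to compound 3 (0.41 log units; beyond the scatter) and so separates them. Across the three compounds shown, the order at this carbon runs bromo, chloro, hydrogen from the lowest number to the highest, with every step beyond the scatter.

As far as these compounds go, whether fluoro, iodo, methoxy or an amine on the same carbon would fit that order remains open, as does the effect of a halogen on another carbon of the ring. No measurement shown accounts for the gap between the two halogens or for their difference from hydrogen.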